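The compounds below may be only part of what the source reports. "The series", "measured", "known", "first", "only" and "open" are said of these compounds alone.

Series notes on the shared core of compound 1 `CC(C)COc1cc(C(F)(F)F)ccc1CNC(=O)C(C)c1ccc(NS(C)(=O)=O)c(F)c1`. In an assay on CHO cells for antagonist activity at transient receptor potential cation channel subfamily V member 1 (Homo sapiens), read by FLIPR (a lower number here means a stronger inhibitor, a higher number a weaker inhibitor), compound 1 gives 0.8 nM. Compound 2 `CC(C(=O)NCc1ccc(C(F)(F)F)cc1OCc1ccccc1)c1ccc(NS(C)(=O)=O)c(F)c1` carries the benzyloxy in place of the isobutoxy of compound 1; in this assay compound 2 gives 0.9 nM. Within the data shown here, the only step measured so far is a 1.1-fold higher number from compound 1 to compound 2 (0.05 log units; within the scatter), so the two numbers cannot be told apart. On the numbers shown compound 2 holds the higher of the two values, but its step from compound 1 lies within the scatter, so no order is claimed.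

Compound 3 `CCCCCc1cc(C(F)(F)F)ccc1CNC(=O)C(C)c1ccc(NS(C)(=O)=O)c(F)c1` is next. Against compound 2 the change is pentyl in place of benzyloxy on an aromatic carbon. Among the measured compounds shown here, no measured step removes the oxygen on the aromatic ring or installs a chain without a ring at this position, so the one step that bears on it only loosely is a 1.1-fold higher number from compound 1 to compound 2 (0.05 log units; within the scatter), which shows that the group at this aromatic carbon tolerated a change of shape without any move beyond the scatter. The expectation for this assay is therefore a step of about a 1.7-fold higher number from compound 2 to compound 3 (0.22 log units; within the scatter), most likely within the scatter or at most a small loss. Compound 3 is estimated at 1.5 nM, with a range from 0.5 nM to 5 nM.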

Compound 3, inhibition constant: 0.4 nM
Compound 3: the middle estimate sits 3.8-fold (0.57 log units) above what was measured; the measured number lies below the stated range.
By their numbers in this assay, from the lowest: compounds 3, 1 and 2 (each within the scatter of the next, the first and the last beyond it).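

In this assay, among these compounds, compound 3 gives 0.4 nM, so this aromatic carbon, ortho to a large group and meta to a trifluoromethyl group, does not need either the oxygen or a ring in its substituent for a value in this range: the earlier compounds both carried an oxygen there, and neither could show this. Among the compounds shown here, the replacement of benzyloxy by pentyl gives a 2.3-fold lower number from compound 2 to compound 3 (0.35 log units; beyond the scatter), the first step to clear the scatter, though only modestly, whereas the replacement of isobutoxy by pentyl gives a 2.0-fold lower number from compound 1 to compound 3 (0.30 log units; within the scatter), so compound 3 and compound 1 cannot be told apart and pentyl cannot be said to outdo every group tried at this carbon. No measurement at hand accounts for the step from benzyloxy to pentyl.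

With the oxygen and the ring leaving together in that step, the compounds shown do not separate their contributions, and a pentyloxy chain or a cyclohexylmethyl group at this carbon would bear on that. Also open, going by these compounds, is how far the tolerance here extends, whether to a longer chain such as decyl or to a chain ending in an amine or a carboxylic acid.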